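Estimating Compound 3 From a Change at a New Place

A few compounds are considered here, and "the series" means these few. Any claim that something is new, unique, unknown or untested is made for them only; others in the source may bear on it.

Measured so far in an ADME assay on HepG2 cells (Homo sapiens) for cytotoxicity, read by luminescence, CellTiter-Glo and ATP content, with a stated time of 72 h; on this read-out lower numbers stand for an effect already at smaller amounts and higher numbers for an effect only at larger amounts of compound:
Compound 1, `COc1ccc(F)cc1CNCCCNc1ccnc2cc(CCC(C)C)ccc12`, gives 890 nM.
Compound 2, `CC(C)CCc1ccc2c(NCCCNCc3ccco3)ccnc2c1`, gives 11200 nM.

In this assay compound 2 stands highest of the two numbers, with compound 1 as its nearest neighbour. Within the data shown here, the one measured step, a 13-fold higher number from compound 1 to compound 2 (1.10 log units; beyond the scatter), concerns a saturated chain carbon bound to an amine nitrogen. Compound 3, `Fc1ccc(Cc2ccc3c(NCCCNCc4ccco4)ccnc3c2)cc1`, differs from compound 2 elsewhere: 4-fluorophenyl in place of isobutyl on a saturated chain carbon bound to an aromatic carbon. Among the measured compounds shown here, no measured step bears on this place, so no step beyond the scatter is expected, only uncertainty. Compound 3 is estimated at 11000 nM, within 3000 nM to 40000 nM. The expected step is therefore a 1.0-fold lower number from compound 2 to compound 3 (0.01 log units; within the scatter).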

Compound 3, half-maximal effective concentration: 5600 nM
For compound 3 the middle estimate is 2.0-fold (0.29 log units) above the measured one; low and high end bracket the measured number.
By their numbers in this assay, from the lowest: compound 1; then compounds 3 and 2 (each within the scatter of the next).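

In this assay, among these compounds, the first measured exchange at this place, 4-fluorophenyl in place of isobutyl on a saturated chain carbon bound to an aromatic carbon, gives a step within the scatter (a 2.0-fold lower number from compound 2 to compound 3 (0.30 log units; within the scatter)). A branched chain and an aromatic ring can therefore stand here without a difference that these two numbers can separate, unlike the large step seen at the other place. Nothing measured here offers an explanation for this result.

As far as these compounds go, it remains open whether an amine or a carboxylic acid at this place would also leave the number within the scatter. From the compounds shown here alone, it is equally open whether the same exchange would read alike with 5-fluoro-2-methoxyphenyl in place of furan-2-yl.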